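Methyl in Place of Amino on a Fused Core

The source may report more compounds than this note shows. Statements on the series, on what has been measured and on what is new or still open speak of the compounds shown alone.

All three measured compounds were tested in a functional assay on the whole organism for inhibition, with Rattus norvegicus as the target, with stated times of 1 h and 3.5 h, at a dose of 100 mg/kg by the oral route; a higher number here means more inhibition at the dose given (going by the name of the read-out), a lower number less inhibition. Compound 1 `Cc1ncc(C)c(-c2ccccc2)n1` gives 12% in this assay, and compound 2 `NC(=O)Nc1nccc(-c2ccncc2)n1` gives 12%. Compound 3 `Nc1ncc2c(n1)CCCCCCCCCC2` gives < 5% in this assay, a limit of the assay and not a number; it stands at the limit of < 5% in this assay, at which 1 of the 3 values shown sits. The unmeasured compound 4 `Cc1ncc2c(n1)CCCCCCCCCC2` differs from compound 3 in one place: methyl in place of amino on an aromatic carbon. Going by the values given here, no step between measured compounds connects these two, so the size of the change cannot be read off the data. Since compound 1 also carries a methyl and shows 12%, the expected step is a number at least 3 percentage points higher from compound 3 to compound 4 (that floor lies within the scatter), no larger than the usual scatter. Compound 4 is therefore estimated at 8%, between 0% and 20%.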

Compound 4, a percentage reported as inhibition, in the whole organism at one dose (the size of the read-out at that dose, not a potency): < 5%
Compound 4: no number, only a limit (the forecaster's own chance of this, stated with the estimate: 45%); at least 3 percentage points between middle value and limit.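

Compound 3 and compound 4 both sit at a limit of the assay, so no step between them can be read: the limit of < 5% in this assay, at which 2 of the 4 values shown sit.

On these data alone, what methyl in place of amino on an aromatic carbon does in this assay stays open.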